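This account rests on a few compounds, and the source may have more. Where it says the series, first, only, none or still open, it means among the compounds named here.

Of the compounds shown here, two have been tested so far in a toxicity assay on HeLa cells (Homo sapiens) for cytotoxicity, read by MTT assay, with a stated time of 48 h; a lower number here means a stronger inhibitor of growth, a higher number a weaker inhibitor of growth. Compound 1 `O=C1NC(=S)S/C1=C\c1cc2cc(Cl)ccc2nc1Cl` gives > 100 ug/mL in this assay, which is a limit of the assay rather than a measured number. Compound 2 `Cc1cccc2cc(/C=C3\SC(=S)NC3=O)c(Cl)nc12` likewise gives > 100 ug/mL in this assay, again a limit and not a number. On the numbers shown, compound 2 stands at the limit of > 100 ug/mL in this assay, at which 2 of the 2 values shown sit, so no difference between the two measured compounds can be read from them. Compound 3 `Cc1cccc2cc(/C=C3\SC(=S)N(CC(=O)O)C3=O)c(Cl)nc12` has not yet been measured. It differs from compound 2 by carboxymethyl in place of hydrogen on an amide-type nitrogen in a ring. Among the measured compounds shown here, no step between measured compounds is known, so the step expected here, a number no higher from compound 2 to compound 3 (the limit leaves the size open), is taken as none beyond the usual scatter, with a good chance that only a limit is reported again. For compound 3 the estimate in this assay is 100 ug/mL, with a range from 40 ug/mL to 300 ug/mL.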

Compound 3, concentration for 50% growth inhibition: > 100 ug/mL
Compound 3 ended at the assay's limit; the forecaster's own chance of this, stated with the estimate: 70%; the middle value lies on the limit itself.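

No step can be read from compound 2 to compound 3, because each stands at a limit of this assay rather than at a number: the limit of > 100 ug/mL in this assay, at which 3 of the 3 values shown sit. The compounds shown leave open how strongly any of them inhibits growth in this assay and whether carboxymethyl in place of hydrogen changes that at all.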